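The source may report more compounds than this note shows. Statements on the series, on what has been measured and on what is new or still open speak of the compounds shown alone.

Of the compounds shown here, three have so far been tested in a functional assay on MDA-MB-231 cells (Homo sapiens) for antiproliferative activity, read by CCK-8 assay, with a stated time of 48 h; a lower number here means a stronger inhibitor, a higher number a weaker inhibitor. Compound 1 `Cc1ccc(-c2[nH]c3ccccc3c2C2=C(Br)C(=O)C(Br)=C(Br)C2=O)cc1` gives 21.6 ug/mL, compound 2 `COc1ccc2[nH]c(C)c(C3=C(Br)C(=O)C(c4c(-c5ccccc5)[nH]c5ccccc45)=C(Br)C3=O)c2c1` gives 5.02 ug/mL, and compound 3 `Cc1ccc(-c2[nH]c3ccccc3c2C2=C(Br)C(=O)C(c3c(C)[nH]c4ccccc34)=C(Br)C2=O)cc1` gives 6.67 ug/mL. Among these three, compound 3 stands second highest: its number sits within the scatter of compound 2 and well apart from compound 1. Going by the values given here, the only single-point step measured so far is a 3.2-fold lower number from compound 1 to compound 3 (0.51 log units; beyond the scatter), in which a bromine on the shared core gave way to an indole group.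

Compound 4 `COc1ccc2[nH]c(C)c(C3=C(Br)C(=O)C(c4c(-c5ccc(C)cc5)[nH]c5ccccc45)=C(Br)C3=O)c2c1` differs from compound 3 in one place: methoxy in place of hydrogen on an aromatic carbon, so that a 2-methyl-1H-indol-3-yl becomes a 5-methoxy-2-methyl-1H-indol-3-yl. Among the compounds with values here, no measured step tests this exact change. Compound 2 does carry the same methoxy group, and its number sits within the scatter of compound 3, but compound 2 also differs from compound 3 elsewhere, so it gives only a loose hint. A small shift, if any beyond the scatter, is therefore expected. Compound 4 is estimated at 5.5 ug/mL, with a range from 2.5 ug/mL to 12 ug/mL. The expected step is a 1.2-fold lower number from compound 3 to compound 4 (0.08 log units; within the scatter).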

Compound 4, half-maximal inhibitory concentration: 3.99 ug/mL
Estimate against measurement, compound 4: 1.4-fold (0.14 log units) above, within the range that was stated.
By their numbers in this assay, from the lowest: compounds 4, 2 and 3 (each within the scatter of the next); then compound 1.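

In this assay, going by these compounds alone, the step of a 1.7-fold lower number from compound 3 to compound 4 (0.22 log units; within the scatter) is the first direct test of methoxy in place of hydrogen on this aromatic carbon, and it shows no shift that can be told apart from the scatter; the added methyl group behind a 1.3-fold lower number from compound 2 to compound 4 (0.10 log units; within the scatter) likewise stays within the scatter. Within the data shown here, replacing bromo on the shared core with the methoxy-bearing 5-methoxy-2-methyl-1H-indol-3-yl gives a 5.4-fold lower number from compound 1 to compound 4 (0.73 log units; beyond the scatter), so this second indole group, like the one in compound 3, stands clearly apart from bromo. No measurement offered here explains why these numbers fall as they do.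

From the compounds shown here alone, whether an amine or a carboxylic acid on this aromatic carbon would move the number beyond the scatter stays open. So does whether an ethoxy group would behave as methoxy does.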